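The source may hold more compounds than are shown below. What is called first, only, known or untested is meant among the compounds shown, and "the series" means these compounds.

Measured in a functional assay on BT-549 cells (Homo sapiens) for cytotoxicity, read by MTT assay, with a stated time of 48 h; a higher number here means a weaker inhibitor, a lower number a stronger inhibitor:
- compound 1 `CCn1c(/C=C2/C(=O)Nc3ccc(C)cc32)nc2ccccc21`: > 50000 nM
- compound 2 `CCn1c(/C=C2/C(=O)Nc3ccc(Br)cc32)nc2ccccc21`: "not determined" (no result reported)
- compound 3 `Cn1c(/C=C2/C(=O)Nc3ccc(Br)cc32)nc2ccccc21`: > 50000 nM

Compound 2 has no single number to stand on, and its entry reads "not determined" (no result reported). Compound 1 gives > 50000 nM, which is a limit of the assay and not a number. Compound 3 gives > 50000 nM, again a limit and not a number. For the measured compounds named here, the series so far therefore offers only (the limit of > 50000 nM in this assay, at which 2 of the 3 values shown sit), and no measured step between any two compounds.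

Compound 4 `CCn1c(/C=C2/C(=O)Nc3ccc(Cl)cc32)nc2ccccc21` is still to be measured in this assay. The structural change is chloro in place of bromo on an aromatic carbon, with chloro in place of bromo on an aromatic carbon. Going by the values given here, with no measured step to size it against, no step beyond the scatter is expected from this exchange, and compound 4 is expected to sit close to the limit reached by its relatives. For compound 4 the estimated value is 45000 nM, with an expected range from 15000 nM to 60000 nM.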

Compound 4, half-maximal inhibitory concentration: > 50000 nM
Compound 4 gave a limit, no number; the forecaster's own chance of this, stated with the estimate: 70%; middle value at least 1.1-fold (0.04 log units) from the limit.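

Compound 4 stands at a limit of the assay, as compound 1 does, so no step can be read between these two compounds: the limit of > 50000 nM in this assay, at which 3 of the 4 values shown sit.

The compounds shown leave open how far any of them lies past that limit, and so what chloro in place of methyl does to the read-out.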